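The source may report more compounds than this note shows. Statements on the series, on what has been measured and on what is new or still open speak of the compounds shown alone.

The measured compounds:
Compound 1, `CCOC(=O)[C@H]1CCN(S(=O)(=O)c2ccc(S(=O)(=O)N(CC)CC)cc2)C1`: in a functional assay on MIA PaCa-2 cells (Homo sapiens) for inhibition, read by MTT assay, with a stated time of 3 days (a higher number here means a weaker inhibitor, a lower number a stronger inhibitor), compound 1 gives > 10000 nM, which is a limit of the assay and not a number.
Compound 2, `CCOC(=O)[C@@H]1CCCN(S(=O)(=O)c2ccc(S(=N)(=O)N(CC)CC)cc2)C1`: in this assay compound 2 gives 900 nM.
Compound 3, `CCOC(=O)[C@@H]1CCCN(S(=O)(=O)c2ccc(C(=O)N(CC)CC)cc2)C1`: in this assay compound 3 gives 100 nM.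

Compound 3 holds the lowest of the two numbers, and compound 2 sits one step away from it: a 9.0-fold lower number from compound 2 to compound 3 (0.95 log units; beyond the scatter). Compound 1 reaches only (the limit of > 10000 nM in this assay, at which 1 of the 3 values shown sits), so it cannot be ranked against the other two.

Compound 4, `CCOC(=O)[C@@H]1CCCN(S(=O)(=O)c2ccc(S(=O)(=O)N(C)C)cc2)C1`, is still to be measured. It differs from compound 3 in one place: dimethylsulfamoyl in place of diethylcarbamoyl on an aromatic carbon. Among the measured compounds shown here, only one measured step touches this position, a 9.0-fold lower number from compound 2 to compound 3 (0.95 log units; beyond the scatter), in which a sulfur-bearing group gave way to the diethylcarbamoyl group and the number fell. Compound 4 goes the other way, back to a sulfur-bearing group, though a different one and with shorter chains on its nitrogen. Compound 1, which carries a related sulfur-bearing group on a different core, gave only a limit. A rise in the number is therefore expected, and the step expected for compound 4 is estimated as a 25-fold higher number from compound 3 to compound 4 (1.40 log units; beyond the scatter). This is broadly of the size of the measured step, though the exact group is new. Compound 4 is expected to give 2500 nM, between 500 nM and 12000 nM.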

Compound 4, half-maximal inhibitory concentration: 300 nM
Compound 4: middle estimate off by 8.3-fold (0.92 log units), on the high side, and the stated range ends above it.
By their numbers in this assay, from the lowest: compound 3; then compound 4; then compound 2. At a limit, above all of these: compound 1.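

In this assay, the place on the aromatic ring para to a large group proves more forgiving of a sulfur-bearing group than compound 2 alone suggested, with a 3.0-fold lower number from compound 2 to compound 4 (0.48 log units; beyond the scatter). Diethylcarbamoyl still holds the lowest number among the measured compounds at this place, and replacing it with dimethylsulfamoyl costs only a 3.0-fold higher number from compound 3 to compound 4 (0.48 log units; beyond the scatter), so the presence of sulfur in this group does not by itself bring the number back to the level of compound 2. Nothing in the data explains why the number moves in either step.

Going by these compounds, the step between compound 2 and compound 4 changes the sulfur-bearing group and shortens the chains on its nitrogen together, so the share of each change stays unknown. Dimethylcarbamoyl or diethylsulfamoyl on the shared core would help to separate the two, while longer chains such as dipropyl, or a nitrogen held in a piperidine ring, would show how much room this place allows.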